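Replacing 3-fluorophenyl with 3,4-dichlorophenyl: notes on the series

The source may report more compounds than this note shows. Statements on the series, on what has been measured and on what is new or still open speak of the compounds shown alone.

Compound 1 `O=C1OC[C@H](Cc2ccccc2)[C@H]1Cc1ccc(Cl)c(Cl)c1` gives 19000 nM
Compound 2 `O=C1OC[C@H](Cc2ccccc2O)[C@H]1Cc1ccc(Cl)c(Cl)c1` gives 33000 nM
Compound 3 `O=C1OC[C@H](Cc2cccc(F)c2)[C@H]1Cc1ccc(Cl)c(Cl)c1` gives 14000 nM

All three values come from a functional assay on HL-60 cells (Homo sapiens) for cytotoxicity, read by WST assay, with a stated time of 48 h (a higher number here means that more compound is needed for the effect, a lower number that less compound is needed), and the three compounds share the core of compound 1. Compound 3 sits with compound 1 at the low end of this narrow range, and it is separated only from compound 2 by a 2.4-fold lower number from compound 2 to compound 3 (0.37 log units; beyond the scatter), a modest gap.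

Compound 4 `O=C1OC[C@H](Cc2ccc(Cl)c(Cl)c2)[C@H]1Cc1ccc(Cl)c(Cl)c1` differs from compound 3 by one change: 3,4-dichlorophenyl in place of 3-fluorophenyl on a saturated chain carbon bound to a saturated ring carbon. In words, this is 3,4-dichlorophenyl in place of 3-fluorophenyl on a saturated chain carbon bound to a saturated ring carbon.

Two further measured steps bear on this group. Fluoro in place of hydrogen gives a 1.4-fold lower number from compound 1 to compound 3 (0.13 log units; within the scatter) and hydroxy in place of hydrogen gives a 1.7-fold higher number from compound 1 to compound 2 (0.24 log units; within the scatter). Changes to this aromatic ring have so far moved the number very little. Going by the values given here, no measured compound carries chloro on this ring, so the data do not test the new group directly.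

The expected step in this assay is therefore small, with nothing beyond the scatter anticipated and the estimate being a 1.2-fold lower number from compound 3 to compound 4 (0.07 log units; within the scatter). For compound 4 the estimated value is 12000 nM within an expected range of 5000 nM to 28000 nM.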

Compound 4, half-maximal effective concentration: 20000 nM
Compound 4: the middle estimate sits 1.7-fold (0.22 log units) below what was measured, within the range that was stated.
By their numbers in this assay, from the lowest: compounds 3, 1, 4 and 2 (each within the scatter of the next, the first and the last beyond it).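

In this assay the first chlorine-bearing ring at this place reads as a 1.4-fold higher number from compound 3 to compound 4 (0.15 log units; within the scatter) and as a 1.1-fold higher number from compound 1 to compound 4 (0.02 log units; within the scatter) and also as a 1.7-fold lower number from compound 2 to compound 4 (0.22 log units; within the scatter) in the comparison with the hydroxy analogue. Going by these compounds alone, compound 4 thus carries the 3,4-dichlorophenyl group twice and still cannot be told apart from compound 1, compound 2 or compound 3, so two chloro groups on this ring, with 8 heavy atoms entering for 7, produce no step beyond the scatter, and the only gap beyond it remains the one separating compound 2 from compound 3. No supporting measurement accompanies these numbers, and nothing explains why this position tolerates the change.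

The compounds shown keep an aromatic carbon ring at this place throughout, so it remains open whether a basic amine or a carboxylic acid on that ring, or a longer chain between that ring and the shared core, would move the number beyond the scatter. Going by these compounds, it also remains open whether this flat response holds when the 3,4-dichlorophenyl group on the other side of the shared core is replaced.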